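Cyano in Place of Bromo on a Shared Amide Core

The compounds below may be only part of what the source reports. "The series", "measured", "known", "first", "only" and "open" are said of these compounds alone.

Compound 1, `COc1cccc(OC)c1C(=O)Nc1nnc(-c2ccc(Cl)cc2)s1`: 3.96
Compound 2, `COc1cccc(OC)c1C(=O)Nc1nnc(-c2ccc(C)cc2)s1`: 3.85
Compound 3, `COc1cccc(OC)c1C(=O)Nc1nnc(-c2ccc(Br)cc2)s1`: 3.96

Three compounds share one core and differ only in the group on the outer benzene ring. In a physicochemical assay for lipophilicity, measured as octanol-water partition (a lower number here means a more polar compound, a higher number a more lipophilic compound), compound 3 gives 3.96, level with compound 1 at the digits shown, and the two together stand highest of the three numbers. The step of no change at the digits printed from compound 1 to compound 3 (within the scatter) and the step of a number 0.11 log units higher from compound 2 to compound 3 (within the scatter) both lie within the scatter, as does a number 0.11 log units lower from compound 1 to compound 2 (within the scatter), so the three measured compounds are indistinguishable in this assay.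

Compound 4, `COc1cccc(OC)c1C(=O)Nc1nnc(-c2ccc(C#N)cc2)s1`, is not yet measured. It differs from compound 3 in one place: cyano in place of bromo on an aromatic carbon. Within the data shown here, the incoming group brings one hydrogen-bond acceptor, which none of the measured groups carries. Among the measured compounds shown here, no measured step covers a change of this kind; the chloro, bromo and methyl swaps all stayed within the scatter and say nothing about a cyano group. The expectation therefore rests on the structural change alone. A step of a number 1.26 log units lower from compound 3 to compound 4 (beyond the scatter) is estimated, downward and beyond the scatter, with a wide range to reflect the missing precedent. For compound 4 the estimated value in this assay is 2.7, between 2.2 and 3.2.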

Compound 4, partition coefficient: 3.14
Compound 4: middle estimate off by 0.44 log units, on the low side; measured number inside the range.
By their numbers in this assay, from the lowest: compound 4; then compounds 2, 1 and 3 (each within the scatter of the next).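

Cyano in place of bromo gives a number 0.82 log units lower from compound 3 to compound 4 (beyond the scatter) in this assay, while cyano in place of methyl gives a number 0.71 log units lower from compound 2 to compound 4 (beyond the scatter) and cyano in place of chloro gives a number 0.82 log units lower from compound 1 to compound 4 (beyond the scatter), so all three comparisons point the same way. The earlier swaps among chloro, bromo and methyl all stayed within the scatter, so they could not show that a change at this place on the outer benzene ring can move the number beyond it. Cyano is also the only one of the four groups counted with a hydrogen-bond acceptor, but nothing available here connects that count to the lower number, and with one such compound it remains a coincidence of two observations.

As far as these compounds go, whether other groups at this place, such as an amine, a carboxylic acid or an acetyl group, would also separate from chloro, bromo and methyl remains open. It is also open whether cyano would give a step of similar size at another place on the ring or on a different core, as all four compounds shown carry their varied group at one place on the shared core.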